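This account rests on a few compounds, and the source may have more. Where it says the series, first, only, none or still open, it means among the compounds named here.

Measured compounds and their values:
compound 1, `CS/C(=N\C(=O)c1ccno1)NC(=O)c1ccno1` — 99200 nM
compound 2, `O=C(/N=C(/NC(=O)c1ccno1)[Se]Cc1ccccc1)c1ccno1` — 53100 nM

Both compounds were tested in a functional assay on PC-3 cells (Homo sapiens) for cytotoxicity, read by MTT assay, with a stated time of 72 h; a higher number here means a weaker inhibitor of growth, a lower number a stronger inhibitor of growth. Compound 2 gives 53100 nM, the lower of the two numbers, while compound 1 gives 99200 nM; the step of a 1.9-fold lower number from compound 1 to compound 2 (0.27 log units; within the scatter) lies within the scatter, so the two cannot be told apart on these data. Compound 3, `C[Se]/C(=N\C(=O)c1ccno1)NC(=O)c1ccno1`, has not yet been measured. It differs from compound 2 in one place: hydrogen in place of phenyl on a saturated chain carbon bound to a selenium atom. Within the data shown here, the only measured step, a 1.9-fold lower number from compound 1 to compound 2 (0.27 log units; within the scatter), is the nearest guide, yet it bundles two changes at once, a methyl becoming a benzyl and a sulfur becoming a selenium, so it cannot isolate the part that compound 3 undoes. Since compound 3 keeps the selenium of compound 2 but carries the methyl of compound 1, its number is expected to fall between those two, and the step of a 1.5-fold higher number from compound 2 to compound 3 (0.18 log units; within the scatter) is expected to stay within the scatter. Compound 3 is therefore estimated at 80000 nM, with a range from 30000 nM to 200000 nM.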

Compound 3, concentration for 50% growth inhibition: 90 nM
Compound 3: the middle estimate sits 890-fold (2.95 log units) above what was measured, outside the stated range (below it).
By their numbers in this assay, from the lowest: compound 3; then compounds 2 and 1 (each within the scatter of the next).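

In this assay, the near-level picture given by the first two compounds breaks down: replacing the phenyl with hydrogen on the saturated chain carbon bound to selenium, which turns benzyl into methyl, gives a 590-fold lower number from compound 2 to compound 3 (2.77 log units; beyond the scatter), so what this position carries can matter greatly when selenium is present. Exchanging sulfur for selenium while keeping the methyl gives a 1100-fold lower number from compound 1 to compound 3 (3.04 log units; beyond the scatter), so the small, unreadable step between compound 1 and compound 2 did not mean that these parts of the molecule were unimportant; among these three compounds, only the one that combines selenium with methyl reaches the low number. Nothing shown here gives a reason for either large step.

As far as these compounds go, it remains open how narrow this requirement is: an ethyl or a longer chain on the selenium would show where between methyl and benzyl the number climbs back, and a benzyl on the sulfur would show how that group behaves without selenium. From the compounds shown here alone, whether the large steps carry over to other cell types also stays unknown, as all three numbers come from a single cell line.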